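Changing the Aryl Sulfone in a Receptor Binding Series

The source may hold more compounds than are shown below. What is called first, only, known or untested is meant among the compounds shown, and "the series" means these compounds.

Measured so far:
Compound 1, `CC1CCN(c2c(S(=O)(=O)c3ccc(F)c(F)c3)cnc3c(F)cccc23)CC1`, 93%
Compound 2, `CC1CCN(c2c(S(=O)(=O)c3cccc(C#N)c3)cnc3ccc(F)cc23)CC1`, 93%
Compound 3, `Cc1ccc(S(=O)(=O)c2cnc3ccc(Cl)cc3c2N2CCC(C)CC2)cc1Cl`, 81%

In an assay on isolated protein for displacement of a labelled ligand from metabotropic glutamate receptor 5 (Homo sapiens), with a stated time of 60 min, tested at 1 uM (a lower number here means less inhibition, a higher number more inhibition at the concentration tested (going by the name of the read-out)), compound 1 gives 93%, level with compound 2 at the digits shown, and together they are the highest of the three numbers. Compound 3 gives 81%, a lower number, a gap beyond the usual scatter. Compound 4, `COc1ccc(S(=O)(=O)c2cnc3c(F)cccc3c2N2CCC(C)CC2)cc1`, has not yet been measured in this assay. It differs from compound 1 in one place: 4-methoxyphenyl in place of 3,4-difluorophenyl on a sulfonyl sulfur. Within the data shown here, no pair of measured compounds isolates such a change, so the size of the step is open. Since compound 2 reaches 93% and compound 1 reaches 93% with different aryl sulfones, a modest downward step or none beyond the scatter is expected, a number 8 percentage points lower from compound 1 to compound 4 (within the scatter). Compound 4 is estimated at 85%, in the range 65% to 97%.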

Compound 4, a percentage reported as inhibition, at one concentration (the size of the read-out at that concentration, not a potency): 67%
For compound 4 the middle estimate is 18 percentage points above the measured one, and the stated range covers the measured number.
By their numbers in this assay, from the lowest: compound 4; then compound 3; then compounds 1 and 2 (each within the scatter of the next).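

Among these compounds, the step gives the first reading of a single change at this position: in this assay, 4-methoxyphenyl in place of 3,4-difluorophenyl on a sulfonyl sulfur gives a number 26 percentage points lower from compound 1 to compound 4 (beyond the scatter), so the aryl groups here are not interchangeable. The two groups match in heavy-atom count, while the entering one carries a hydrogen-bond acceptor. Nothing available explains the fall.

Whether it tracks the methoxy group's arrival or the fluorines' departure stays open, as plain phenyl is not among the compounds shown. Also open, as far as these compounds go, is how an amine or carboxylic acid on that ring would read.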